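This account rests on a few compounds, and the source may have more. Where it says the series, first, only, none or still open, it means among the compounds named here.

This account follows the step from compound 1 `ClCc1ccc(Cn2cnc3c(Cl)ncnc32)cc1` to compound 3 `ClCc1ccc(Cn2cnc3c(Cl)nc(Cl)nc32)cc1`. In a functional assay on SF-295 cells (Homo sapiens) for cytotoxicity, read by sulforhodamine B assay, with a stated time of 48 h (a lower number here means a stronger inhibitor of growth, a higher number a weaker inhibitor of growth), compound 1 gives 3460 nM. Among the two compounds measured so far, compound 1 has the highest number; its nearest neighbour is compound 2 `ClCc1cccc(Cn2cnc3nc(Cl)nc(Cl)c32)c1`, which in this assay gives 3380 nM, a gap that lies within the usual scatter, so the two cannot be told apart on these numbers. Compound 3 differs from compound 1 in one place: chloro in place of hydrogen on an aromatic carbon. The chlorine enters on an aromatic carbon of the six-membered ring of the shared core, between two ring nitrogen atoms. For the measured compounds named here, no step between two measured compounds isolates this change, so its effect has not been seen directly. Compound 2, whose core also carries two chloro groups and which differs from compound 1 in more than one place, gives a number indistinguishable from that of compound 1 in this assay. On that basis the step is expected to be small, not beyond the scatter: a 1.2-fold lower number from compound 1 to compound 3 (0.06 log units; within the scatter). Compound 3 is therefore estimated to give 3000 nM in this assay, with a range from 1200 nM to 7500 nM.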

Compound 3, concentration for total growth inhibition: 19500 nM
The estimate for compound 3 lay 6.5-fold (0.81 log units) below the measured number; the whole stated range lies below it.
By their numbers in this assay, from the lowest: compounds 2 and 1 (each within the scatter of the next); then compound 3.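

In this assay, chloro in place of hydrogen on this aromatic carbon, between two ring nitrogen atoms, gives a 5.6-fold higher number from compound 1 to compound 3 (0.75 log units; beyond the scatter), a step beyond the scatter and toward weaker inhibition of growth. For the compounds shown here, this is the first direct reading of the position, and it shows that the position is not indifferent to this change: a single added chlorine is enough to move the number. Compound 2 also carries two chloro groups on its core, but it differs from compound 1 in more than one place, so its number could not show this, and nothing available explains the size or direction of the step.

On these data alone, it remains open whether this loss is particular to chloro or would also follow from another group on the same carbon, such as an amine, a methoxy group or a methyl group. Whether the same step would appear with the chloromethyl group placed as it is in compound 2 also stays unresolved, as a single step at one position cannot settle it.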